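Aryl replacement on a carbonyl carbon in a cytotoxicity series

The source may hold more compounds than are shown below. What is called first, only, known or untested is meant among the compounds shown, and "the series" means these compounds.

Compound 1 `O=C(/C=C/c1ccc2c(c1)B(O)OC2)c1ccco1`: 24100 nM
Compound 2 `O=C(/C=C/c1ccc2c(c1)B(O)OC2)c1ccc(F)cc1`: 2800 nM

In a functional assay on HCT-116 cells (Homo sapiens) for cytotoxicity, read by MTT assay, with a stated time of 48 h (on this read-out lower numbers stand for stronger inhibition and higher numbers for weaker inhibition), compound 1 gives 24100 nM, the highest of the two numbers shown; its nearest neighbour, compound 2, gives 2800 nM. Compound 3 `O=C(/C=C/c1ccc2c(c1)B(O)OC2)c1ccccc1O` has not yet been measured. It differs from compound 1 by 2-hydroxyphenyl in place of furan-2-yl on a carbonyl carbon. For the measured compounds named here, the one measured step that bears on this change is an 8.6-fold lower number from compound 1 to compound 2 (0.93 log units; beyond the scatter), which likewise exchanged furan-2-yl for a six-membered aromatic ring of carbon only on a carbonyl carbon. Going by the values given here, no measured step shows the effect of the 2-hydroxyphenyl group itself. Compound 3 is therefore expected to show a step of a 5.4-fold lower number from compound 1 to compound 3 (0.73 log units; beyond the scatter) in this assay, towards a lower number, of a size comparable to, though not necessarily equal to, the step seen for compound 2. The estimate for compound 3 is 4500 nM, with a range from 1500 nM to 14000 nM.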

Compound 3, half-maximal inhibitory concentration: 77900 nM
Estimate against measurement, compound 3: 17-fold (1.24 log units) below, outside the stated range (above it).
By their numbers in this assay, from the lowest: compound 2; then compound 1; then compound 3.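

In this assay, a six-membered aromatic ring of carbon only on the carbonyl carbon does not in itself bring a lower number: 2-hydroxyphenyl in place of furan-2-yl gives a 3.2-fold higher number from compound 1 to compound 3 (0.51 log units; beyond the scatter), opposite in direction to the step seen with 4-fluorophenyl. The two six-membered rings also stand well apart, with a 28-fold higher number from compound 2 to compound 3 (1.44 log units; beyond the scatter), so across these three compounds the outcome depends on the particular aryl group and not on ring size alone. Nothing available accounts for this reversal.

The compounds shown leave open whether the hydroxyl group itself or its place on the ring sets the higher number of compound 3. They also leave open whether plain phenyl, 4-hydroxyphenyl, 2-methoxyphenyl or 2-aminophenyl would fall nearer to compound 2 or to compound 3.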